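The compounds below may be only part of what the source reports. "The series", "measured", "known", "first", "only" and "open" are said of these compounds alone.

Series notes. Compound 1 `Fc1cccc(Cl)c1-c1ncco1` gives 1.89 in a physicochemical assay for lipophilicity (on this read-out higher numbers stand for higher lipophilicity and lower numbers for lower lipophilicity), and compound 2 `Fc1cccc(F)c1-c1ncco1` gives 1.45 in this assay. The change from compound 1 to compound 2 is fluoro in place of chloro on an aromatic carbon, and its step is a number 0.44 log units lower from compound 1 to compound 2 (beyond the scatter).

Compound 3 `Fc1cccc(Cl)c1C1=NC(c2ccccc2)CO1` gives 3.45 in this assay. How the core of compound 3 differs from the core of compound 1 is not broken down here.

Compound 4 `Fc1cccc(F)c1C1=NC(c2ccccc2)CO1` is not yet measured. The change from compound 3 to compound 4 is fluoro in place of chloro on an aromatic carbon, the same kind of change as that from compound 1 to compound 2; the surroundings differ only in that the fluoro enters ortho to a large group rather than ortho to a group of 5 heavy atoms. For the measured compounds named here, the expected step for compound 4 is a number 0.44 log units lower from compound 3 to compound 4 (beyond the scatter), resting on the single measured instance a number 0.44 log units lower from compound 1 to compound 2 (beyond the scatter). Compound 4 is therefore estimated at 3.01 in this assay, between 2.65 and 3.35.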

Compound 4, partition coefficient: 3.01
Compound 4: the middle estimate sits on the measured number at the digits printed, and the stated range covers the measured number.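

In this assay, the step of a number 0.44 log units lower from compound 3 to compound 4 (beyond the scatter) matches in size the step of a number 0.44 log units lower from compound 1 to compound 2 (beyond the scatter) and so, for these two pairs, fluoro in place of chloro on an aromatic carbon carries from the core of compound 1 to the core of compound 3 with no change in size. These two pairs alone do not show that the same step would hold on any further core or for any other replacement at this place. Nothing measured here gives a reason for the match.

The compounds shown hold only chloro and fluoro at this place. On these data alone, how an amine, a carboxylic acid or a longer chain there would read in this assay stays open, as does whether the step survives on a core carrying such a group.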